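Moving the aryl substituent: from 2-aminophenyl to 4-carboxyphenyl

The source may report more compounds than this note shows. Statements on the series, on what has been measured and on what is new or still open speak of the compounds shown alone.

Compound 1, `Nc1ccccc1-c1cnc(C(=O)CCCCCCc2ccccc2)o1`, gives 750 nM in an assay (Rattus norvegicus) for inhibition of Fatty-acid amide hydrolase 1 (Homo sapiens); on this read-out higher numbers stand for weaker inhibition and lower numbers for stronger inhibition.
Compound 2, `N#Cc1ccccc1-c1cnc(C(=O)CCCCCCc2ccccc2)o1`, gives 130 nM in this assay.
Compound 3, `Nc1ccc(-c2cnc(C(=O)CCCCCCc3ccccc3)o2)cc1`, gives 90 nM in this assay.

Among these three numbers compound 1 stands highest, that is, it is the weakest inhibitor of the set. The two steps away from it are both beyond the scatter: a 5.8-fold lower number from compound 1 to compound 2 (0.76 log units; beyond the scatter) and an 8.3-fold lower number from compound 1 to compound 3 (0.92 log units; beyond the scatter). Compound 2 and compound 3 lie within the scatter of each other (a 1.4-fold lower number from compound 2 to compound 3 (0.16 log units; within the scatter)), so no order between them can be claimed.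

Compound 4, `O=C(O)c1ccc(-c2cnc(C(=O)CCCCCCc3ccccc3)o2)cc1`, has not yet been measured. It differs from compound 1 in one place: 4-carboxyphenyl in place of 2-aminophenyl on an aromatic carbon. Within the data shown here, two measured steps bear on this change. Shifting the amino group from the 2- to the 4-position gave an 8.3-fold lower number from compound 1 to compound 3 (0.92 log units; beyond the scatter), and swapping the group itself gave a 5.8-fold lower number from compound 1 to compound 2 (0.76 log units; beyond the scatter). Neither step tests a carboxy group directly, so the evidence is indirect. Since both changes starting from compound 1 lowered the number beyond the scatter, a modest step lower is expected, a 3.0-fold lower number from compound 1 to compound 4 (0.48 log units; beyond the scatter). The estimate for compound 4 in this assay is 250 nM, with a range from 60 nM to 1000 nM.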

Compound 4, inhibition constant: 60 nM
Estimate against measurement, compound 4: 4.2-fold (0.62 log units) above; the measured number falls inside the stated range.
By their numbers in this assay, from the lowest: compounds 4, 3 and 2 (each within the scatter of the next, the first and the last beyond it); then compound 1.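

Replacing 2-aminophenyl with 4-carboxyphenyl in this assay gives the first step from compound 1 that is graded large (a 13-fold lower number from compound 1 to compound 4 (1.10 log units; beyond the scatter)), so a low number at this position does not depend on keeping an amino group. With the group at the same place on the phenyl ring, carboxy and amino cannot be told apart (a 1.5-fold lower number from compound 3 to compound 4 (0.18 log units; within the scatter)), which means that two quite different substituents give matching results here. Among these compounds, compound 2 and compound 3 could not be separated, but the comparison with the nitrile does show a modest difference beyond the scatter (a 2.2-fold lower number from compound 2 to compound 4 (0.34 log units; beyond the scatter)), and this is the only step among the three lower compounds that can be given a direction.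

Why 2-aminophenyl gives the highest number while the other three groups all sit lower is something no available measurement explains.
From the compounds shown here alone, it also stays open whether a methyl ester or a hydroxy group in place of the carboxy group of compound 4, or a plain phenyl ring with no substituent at all, would give a number like those of compound 3 and compound 4.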